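Replacing the ((ethoxycarbonyl)carbonyl)amino group: expected paw edema inhibition

The source may hold more compounds than are shown below. What is called first, only, known or untested is meant among the compounds shown, and "the series" means these compounds.

Among the measured compounds shown here, compound 2 `CCOC(=O)C(=O)NC1=C(C#N)C2C(N3CCCC3)CCCCN2C(=O)N1c1ccccc1` gives 91.5% in a functional assay on the whole organism (strain albino) for inhibition, with Rattus norvegicus as the target, read by paw edema, with stated times of 1 h and 3 h, at a dose of 20 mmol/kg by the intraperitoneal route (a higher number here means a stronger effect of the compound at the dose given, a lower number a weaker effect), the highest of the two numbers so far. For the measured compounds named here, its nearest neighbour is compound 1 `N#CC1=C(NCC(=O)N2CCOCC2)N(c2ccccc2)C(=O)N2CCCCC(N3CCCC3)C12`, which in this assay gives 73.5%; the only measured step, a number 18 percentage points higher from compound 1 to compound 2 (beyond the scatter), is modest but beyond the scatter.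

Compound 3 `COc1ccc(/C=N/C2=C(C#N)C3C(N4CCCC4)CCCCN3C(=O)N2c2ccccc2)cc1` differs from compound 2 as follows: a group of 10 heavy atoms (8 carbon, 1 nitrogen, 1 oxygen; one six-membered aromatic ring of carbon only) in place of a group of 8 heavy atoms (4 carbon, 1 nitrogen, 3 oxygen; no ring), on a double-bonded ring carbon. Going by the values given here, the one measured step bears on this only loosely: it exchanged the substituent on an amine nitrogen and raised the read-out modestly, whereas compound 3 removes that nitrogen-borne substituent altogether and takes away the single hydrogen-bond donor of compound 2. Among the compounds with values here, no measured step reports such a change, so no direction can be read from the data beyond noting that both measured compounds sit in the upper part of the scale. Compound 3 is therefore expected to land near the level of compound 1, a step of a number 16.5 percentage points lower from compound 2 to compound 3 (beyond the scatter) from compound 2, with a range wide enough to include no change within the scatter. The estimate for compound 3 in this assay is 75%, between 50% and 92%.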

Compound 3, a percentage reported as inhibition, in the whole organism at one dose (the size of the read-out at that dose, not a potency): 75.3%
For compound 3 the middle estimate is 0.3 percentage points below the measured one; low and high end bracket the measured number.
By their numbers in this assay, from the lowest: compounds 1 and 3 (each within the scatter of the next); then compound 2.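

In this assay, replacing the ((ethoxycarbonyl)carbonyl)amino group on the double-bonded ring carbon with the group of 10 heavy atoms bearing a six-membered aromatic ring of carbon only gives a number 16.2 percentage points lower from compound 2 to compound 3 (beyond the scatter), so this position does respond to the choice of substituent and the highest read-out so far stays with compound 2. The two ring-bearing groups of 10 heavy atoms, one with an aromatic ring of carbon only and the other with a non-aromatic ring with 2 hetero atoms, cannot be told apart at this dose, with a number 1.8 percentage points higher from compound 1 to compound 3 (within the scatter), which puts two quite different groups at one level on the shared core. No measurement at hand offers an explanation for either step.

The compounds shown leave open whether the higher read-out of compound 2 depends on the ethyl ester, which a free carboxylic acid or a simple acetyl group at the same nitrogen would test, or whether an unsubstituted amine at this position would hold the same level. All three read-outs also come from a single dose, so the steps describe only a stronger or weaker effect at that dose.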